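A few compounds are considered here, and "the series" means these few. Any claim that something is new, unique, unknown or untested is made for them only; others in the source may bear on it.

Measured so far:
- compound 1 `CCOC(=O)c1cnc(C(C)(C)C)nc1NN1C(=O)C=C(C)C1=O`: 1000 nM
- compound 2 `CCOC(=O)c1cnc(-c2cccc(Br)c2)nc1NN1C(=O)C=C(C)C1=O`: 700 nM

In a functional assay on Jurkat cells for inhibition of nuclear factor NF-kappa-B complex (Homo sapiens) (on this read-out higher numbers stand for weaker inhibition and lower numbers for stronger inhibition), compound 1 gives 1000 nM, while compound 2 gives 700 nM. Within the data shown here, compound 2 carries the lower of the two numbers, but the single measured step, a 1.4-fold lower number from compound 1 to compound 2 (0.15 log units; within the scatter), lies within the scatter, so the two compounds cannot be told apart on this read-out.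

Compound 3 `CCOC(=O)c1cnc(-c2ccc(Cl)s2)nc1NN1C(=O)C=C(C)C1=O` is the next compound in line. Compared with compound 2 the change is 5-chlorothiophen-2-yl in place of 3-bromophenyl on an aromatic carbon, so one flat aromatic ring bearing a halogen is swapped for another of the same kind. Among the measured compounds shown here, the one step measured so far, from compound 1 to compound 2, replaced a branched alkyl group by an aromatic ring and is therefore a different kind of change; no measured step swaps one halogenated aromatic ring for another. There is thus no basis for expecting a shift beyond the scatter.

Compound 3 is estimated at 700 nM in this assay, with a range from 250 nM to 2000 nM. That estimate corresponds to an expected step of no change at the digits printed from compound 2 to compound 3 (within the scatter).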

Compound 3, half-maximal inhibitory concentration: 300 nM
The estimate for compound 3 lay 2.3-fold (0.37 log units) above the measured number; measured number inside the range.
By their numbers in this assay, from the lowest: compound 3; then compounds 2 and 1 (each within the scatter of the next).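

In this assay this position on the shared core now gives a change that can be read: 5-chlorothiophen-2-yl in place of 3-bromophenyl produces a 2.3-fold lower number from compound 2 to compound 3 (0.37 log units; beyond the scatter) while the earlier swap of tert-butyl for 3-bromophenyl stayed within the scatter. Measured against the tert-butyl group, 5-chlorothiophen-2-yl gives a 3.3-fold lower number from compound 1 to compound 3 (0.52 log units; beyond the scatter) so the group on this aromatic carbon can shift the number, though only modestly so far. No measurement shown here accounts for the shift.

Each of the two aromatic groups carries its own halogen on its own ring, so the compounds shown cannot separate the contribution of the sulfur-containing ring from that of the chlorine. They also leave open how plain thiophen-2-yl, or an amine or a carboxylic acid on the same carbon, would behave.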